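Swapping 3-fluorophenyl for 2-iodophenyl on a carbonyl carbon

A few compounds are considered here, and "the series" means these few. Any claim that something is new, unique, unknown or untested is made for them only; others in the source may bear on it.

Among the compounds with values here, in a functional assay on HepG2 cells (Homo sapiens) for inhibition, read by MTT assay (a lower number here means a stronger inhibitor, a higher number a weaker inhibitor), compound 2 `COc1cc2ncnc(Nc3ccc(NC(=O)c4cccc(F)c4)cc3)c2cc1OC` gives 8200 nM, the only actual number so far. Compound 1 `COc1cc2ncnc(Nc3ccc(NC(=O)c4ccccc4OC)cc3)c2cc1OC` reaches only a limit, > 100000 nM. Compound 3 `COc1cc2ncnc(Nc3ccc(NC(=O)c4ccccc4I)cc3)c2cc1OC` differs from compound 2 by 2-iodophenyl in place of 3-fluorophenyl on a carbonyl carbon, with 2-iodophenyl in place of 3-fluorophenyl on a carbonyl carbon. Within the data shown here, one measured step bears on this, and it is large: an at least 12-fold lower number from compound 1 to compound 2 (1.08 log units; beyond the scatter). Going by that step, losing 3-fluorophenyl for a group named like the 2-methoxyphenyl of compound 1 should weaken inhibition, though a single step is thin support. The expected change is a 3.7-fold higher number from compound 2 to compound 3 (0.56 log units; beyond the scatter). For compound 3 the estimated value is 30000 nM, with a range of 8000 nM to 100000 nM.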

Compound 3, half-maximal inhibitory concentration: 33000 nM
Estimate against measurement, compound 3: 1.1-fold (0.04 log units) below; low and high end bracket the measured number.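

Putting 2-iodophenyl in place of 3-fluorophenyl on the carbonyl carbon weakens inhibition, with a 4.0-fold higher number from compound 2 to compound 3 (0.60 log units; beyond the scatter). Iodo in place of methoxy on an aromatic carbon strengthens it, with an at least 3.0-fold lower number from compound 1 to compound 3 (0.48 log units; beyond the scatter), so compound 3 gives a measurable value on the same ring position where compound 1 does not. Compound 1 stands only as a limit, so the true size of that second step stays unknown: the limit of > 100000 nM in this assay, at which 1 of the 3 values shown sits.

On these data alone, whether the loss from compound 2 to compound 3 follows the change of halogen or the change of its place stays open. A 2-fluorophenyl or 3-iodophenyl group would separate the two, and an amine on this ring could show whether a group other than a halogen or methoxy is tolerated.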